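Chloro to trifluoromethyl swap in a small cytotoxicity series

The compounds below may be only part of what the source reports. "The series", "measured", "known", "first", "only" and "open" are said of these compounds alone.

Measured so far:
compound 1, `O=C1C(=O)N(CN2CCN(c3ccnc4cc(Cl)ccc34)CC2)c2cccc(Br)c21`: 15100 nM
compound 2, `O=C1C(=O)N(CN2CCN(c3ccnc4cc(Cl)ccc34)CC2)c2cc(Cl)ccc21`: 26100 nM
compound 3, `O=C1C(=O)N(CN2CCN(c3ccnc4cc(C(F)(F)F)ccc34)CC2)c2cccc(Br)c21`: 66800 nM

All three were run in a functional assay on MCF7 cells (Homo sapiens) for cytotoxicity, read by sulforhodamine B assay, with a stated time of 48 h; on this read-out higher numbers stand for weaker inhibition of growth and lower numbers for stronger inhibition of growth. Compound 3 differs from compound 1 by trifluoromethyl in place of chloro on an aromatic carbon and the step is a 4.4-fold higher number from compound 1 to compound 3 (0.65 log units; beyond the scatter). Compound 2 and compound 1 have different cores; the difference between the two cores is not broken down here, and their two values lie within the scatter of each other, so no order is drawn between them. Compound 2 against compound 3 does fall beyond the scatter, compound 3 showing the higher number.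

Compound 4, `O=C1C(=O)N(CN2CCN(c3ccnc4cc(C(F)(F)F)ccc34)CC2)c2cc(Cl)ccc21`, is not yet measured. It differs from compound 2 by trifluoromethyl in place of chloro on an aromatic carbon, the same change as from compound 1 to compound 3. Among the compounds with values here, because a 4.4-fold higher number from compound 1 to compound 3 (0.65 log units; beyond the scatter) sets the only precedent for this change, a step of similar size is expected, a 3.8-fold higher number from compound 2 to compound 4 (0.58 log units; beyond the scatter). On that basis compound 4 is estimated at 100000 nM in this assay, with an expected range from 40000 nM to 250000 nM.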

Compound 4, concentration for 50% growth inhibition: 15800 nM
For compound 4 the middle estimate is 6.3-fold (0.80 log units) above the measured one; measured number below the stated range.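

In this assay, trifluoromethyl in place of chloro on an aromatic carbon does not carry over from one core to the other as a step of one size: the same change on two cores in this assay, a 4.4-fold higher number (0.65 log units; beyond the scatter) from compound 1 to compound 3 and a 1.7-fold lower number (0.22 log units; within the scatter) from compound 2 to compound 4, 7.3-fold (0.86 log units) apart, beyond the scatter of two such steps

On the core of compound 2 the change gives a 1.7-fold lower number from compound 2 to compound 4 (0.22 log units; within the scatter), so no order is drawn within that pair, whereas on the core of compound 1 it gives a 4.4-fold higher number from compound 1 to compound 3 (0.65 log units; beyond the scatter). With a single pair on each core, this shows that the step depends on the core in these four compounds, but it does not show which part of the core difference is responsible, nor what the change would do on a third core.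

The compounds shown leave open whether other groups on the same aromatic carbon, such as a methoxy, a nitrile or an amine, would also give steps that differ between the two cores. Also open, on these data alone, is how the step would run on a core carrying fluoro or methyl in place of the bromo of compound 1.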